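From tert-butyl to chloro in a potent antiproliferative compound

The source may hold more compounds than are shown below. What is called first, only, known or untested is meant among the compounds shown, and "the series" means these compounds.

- compound 1 `CC(C)(C)c1ccc(OCCCON2C(N)=NC(N)=NC23CCSCC3)cc1` gives 1 nM
- compound 2 `Cc1ccc(OCCCON2C(N)=NC(N)=NC23CCOCC3)cc1` gives 2390 nM

In a functional assay on HCT-116 cells (Homo sapiens) for antiproliferative activity, read by MTT assay, with a stated time of 72 h (a lower number here means a stronger inhibitor, a higher number a weaker inhibitor), compound 1 stands lowest of the two at 1 nM while compound 2 reads 2390 nM beyond the scatter. Compound 3 `NC1=NC2(CCSCC2)N(OCCCOc2ccc(Cl)cc2)C(N)=N1` keeps the core of compound 1 but has chloro in place of tert-butyl on an aromatic carbon para to a large group. Among the compounds with values here, no measured pair isolates this change. Because compound 1 sits at 1 nM a rise beyond the scatter is expected in this assay as the likelier outcome. The expected size is a 30-fold higher number from compound 1 to compound 3 (1.48 log units; beyond the scatter) toward weaker inhibition. Compound 3 is estimated at 30 nM with an expected range from 3 nM to 300 nM in this test.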

Compound 3, half-maximal inhibitory concentration: 10 nM
Compound 3: middle estimate off by 3.0-fold (0.48 log units), on the high side; measured number inside the range.
By their numbers in this assay, from the lowest: compound 1; then compound 3; then compound 2.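

Within the data shown here, the change from tert-butyl to chloro, on an aromatic carbon para to a large group, gives the first direct reading at this position in this assay: a 10-fold higher number from compound 1 to compound 3 (1.00 log units; beyond the scatter). The loss is real, yet compound 3 still gives 10 nM, so this position tolerates a single chlorine in place of the larger tert-butyl with activity retained. Nothing measured here accounts for the size of this step. The compounds shown leave open how methoxy, trifluoromethyl or an amine would read on this carbon, and whether the same step would hold on another core.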